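Swapping Dimethylamino for Acetyl on a Shared Core

The compounds below may be only part of what the source reports. "The series", "measured", "known", "first", "only" and "open" are said of these compounds alone.

Compound 1 `COc1cc(C)cc(-c2c(-c3ccnc(-c4ccc(N(C)C)cc4)c3)cnn2CC#N)c1` is the starting point. In a functional assay on NCI/ADR-RES cells (Homo sapiens) for inhibition, read by sulforhodamine B assay, with a stated time of 48 h (a higher number here means that more compound is tolerated, a lower number that less compound is tolerated), compound 1 gives > 100000 nM, which is a limit of the assay rather than a measured number. Where compound 1 stands is told only by the limit of > 100000 nM in this assay, at which 1 of the 2 values shown sits. Among the compounds with values here, compound 2 `Cc1cc(O)cc(-c2nn(CC#N)cc2-c2ccnc(-c3ccc(Oc4ccccc4)cc3)c2)c1` differs in several places, so no single step connects it to compound 1; in this assay compound 2 gives 15800 nM. Compound 3 `COc1cc(C)cc(-c2c(-c3ccnc(-c4ccc(C(C)=O)cc4)c3)cnn2CC#N)c1` is not yet measured. It differs from compound 1 in one place (acetyl in place of dimethylamino on an aromatic carbon). Within the data shown here, no measured step of this kind exists, so a change of no more than modest size, in either direction or none beyond the scatter, is expected. Compound 3 is estimated at 60000 nM, between 15000 nM and 200000 nM. This estimate means the step of an at least 1.6-fold lower number from compound 1 to compound 3 (0.22 log units; that floor lies within the scatter).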

Compound 3, concentration lethal to 50% of the cells: > 100000 nM
Compound 3 was reported as a limit (the forecaster's own chance of this, stated with the estimate: 50%); middle value at least 1.6-fold (0.22 log units) from the limit.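

Within the data shown here, compound 1 and compound 3 both stop at a limit of the assay rather than giving a number, so no step between them can be read: the limit of > 100000 nM in this assay, at which 2 of the 3 values shown sit. In this assay, as far as these compounds go, it stays open whether acetyl in place of dimethylamino changes the reading at all.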